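Amino to Nitro at the Amide End: Expecting Compound 4

The source may report more compounds than this note shows. Statements on the series, on what has been measured and on what is new or still open speak of the compounds shown alone.

Compound 1, `Cc1cc(S(=O)(=O)N2C(=O)N[C@@H](c3ccccc3)C2C)ccc1NC(=O)c1ccc([N+](=O)[O-])cc1`, gives > 10000 nM in a functional assay on HCT-116 cells (Homo sapiens) for cytotoxicity, read by MTT assay (on this read-out higher numbers stand for weaker inhibition and lower numbers for stronger inhibition), which is a limit of the assay and not a number.
Compound 2, `CCOC(=O)Nc1ccc(S(=O)(=O)N2C(=O)N[C@@H](c3ccccc3)C2C)cc1Cl`, gives 5500 nM in this assay.
Compound 3, `CC1[C@H](c2ccccc2)NC(=O)N1S(=O)(=O)c1ccc(NC(=O)c2ccc(N)cc2)c(Cl)c1`, gives > 10000 nM in this assay, again a limit rather than a number.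

Compound 3 therefore stands at the top end of what the assay reports, where (the limit of > 10000 nM in this assay, at which 2 of the 3 values shown sit); only compound 2 yields a real number. Among the compounds with values here, the one measured step that touches the amide end, an at least 1.8-fold higher number from compound 2 to compound 3 (0.25 log units; that floor lies within the scatter), moved the value from a number to a limit. The change now considered is nitro in place of amino on an aromatic carbon, giving compound 4, `CC1[C@H](c2ccccc2)NC(=O)N1S(=O)(=O)c1ccc(NC(=O)c2ccc([N+](=O)[O-])cc2)c(Cl)c1`. Compound 1 carries the same nitro-bearing amide and differs from compound 4 only elsewhere. Its value is a limit, which points the same way as the value of compound 3. For compound 4 a step that the limit leaves unreadable from compound 3 to compound 4 is expected, meaning essentially no change beyond the scatter. The estimate for compound 4 in this assay is 15000 nM, with a range from 5000 nM to 50000 nM, most likely reported again as a limit.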

Compound 4, half-maximal inhibitory concentration: > 10000 nM
Compound 4 was reported as a limit; the forecaster's own chance of this, stated with the estimate: 70%; the middle value lies beyond the limit too.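

With nitro in place of amino, the amide end still gives no number in this assay, and the steps joining compound 4 to compound 3 and to compound 1 cannot be read, because all three compounds sit at one limit: the limit of > 10000 nM in this assay, at which 3 of the 4 values shown sit.

Within the data shown here, the one readable comparison is an at least 1.8-fold higher number from compound 2 to compound 4 (0.25 log units; that floor lies within the scatter), so it does not separate the 4-nitrophenyl group from the ethoxy group on that carbonyl carbon. Amino and nitro have now both been tried at this place on the chloro-bearing compound, and neither gives a number.

The compounds shown leave open whether a carboxylic acid or a methoxy group at this place would bring a value that can be read. They also leave open how far apart compound 3 and compound 4 truly lie.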